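The source may hold more compounds than are shown below. What is called first, only, known or untested is meant among the compounds shown, and "the series" means these compounds.

Measured compounds:
compound 1 `Cc1cc(Nc2cc(-c3ccccc3)[nH]n2)n2nc(SCc3cccc(Br)c3)nc2n1`, 8900 nM
compound 2 `Cc1cc(Nc2cc(-c3ccccc3)[nH]n2)n2nc(SCc3ccc(C(F)(F)F)cc3)nc2n1`, 4240 nM

Both numbers come from a functional assay on PC-9 cells (Homo sapiens) for inhibition, read by MTT assay, with a stated time of 72 h; a higher number here means a weaker inhibitor, a lower number a stronger inhibitor. Going by the values given here, compound 2 holds the lower of the two numbers, its nearest neighbour being compound 1; the single measured step is a 2.1-fold lower number from compound 1 to compound 2 (0.32 log units; beyond the scatter).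

Compound 3 `C=CCSc1nc2nc(C)cc(Nc3cc(-c4ccccc4)[nH]n3)n2n1` is not yet measured. It differs from compound 2 by vinyl in place of 4-(trifluoromethyl)phenyl on a saturated chain carbon bound to a sulfur. Among the compounds with values here, the one measured step swaps one six-membered aromatic ring of carbon only for another and does not bear on losing the ring altogether, so no direct guide exists; the expected direction is toward a weaker inhibitor. The step expected is a 2.2-fold higher number from compound 2 to compound 3 (0.35 log units; beyond the scatter). Compound 3 is estimated at 9500 nM, within 3000 nM to 30000 nM.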

Compound 3, half-maximal inhibitory concentration: > 50000 nM
Compound 3 ended at the assay's limit (the forecaster's own chance of this, stated with the estimate: 15%); middle value at least 5.2-fold (0.72 log units) away from the limit.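

In this assay, this position on the saturated chain carbon bound to a sulfur tolerates one ring-bearing group in place of another far better than it tolerates loss of the ring: the change to vinyl gives an at least 11-fold higher number from compound 2 to compound 3 (1.07 log units; beyond the scatter) and an at least 5.6-fold higher number from compound 1 to compound 3 (0.74 log units; beyond the scatter). Both ring-bearing compounds return measurable values, whereas compound 3 stands at a limit of the assay, not at a number: the limit of > 50000 nM in this assay, at which 1 of the 3 values shown sits.

On these data alone, it remains open whether the ring itself matters or only the number of heavy atoms the group carries. A longer alkyl chain, a cyclohexyl group or an unsubstituted phenyl at this place would separate these readings.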